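The compounds below may be only part of what the source reports. "The series", "measured", "known", "first", "only" and "open" are said of these compounds alone.

In a functional assay on K562 cells (Homo sapiens) for inhibition, read by fluorescence, with a stated time of 72 h (on this read-out higher numbers stand for weaker inhibition of growth and lower numbers for stronger inhibition of growth), compound 2 `CC(C)CCn1cnc2c(Nc3cccc(Cl)c3)nc(N[C@H]3CC[C@H](N)CC3)nc21` gives 1500 nM, the lowest of the three numbers, against compound 3 `CC(C)CCn1cnc2c(Nc3ccccc3)nc(N[C@H]3CC[C@H](N)CC3)nc21` at 3500 nM and compound 1 `CCCCn1cnc2c(NCc3cccc(Cl)c3)nc(N[C@H]3CC[C@H](N)CC3)nc21` at 4300 nM. Compound 4 `CCCCn1cnc2c(Nc3cccc(Cl)c3)nc(N[C@H]3CC[C@H](N)CC3)nc21` differs from compound 2 as follows: hydrogen in place of methyl on a saturated chain carbon bound to two saturated chain carbons. This is hydrogen in place of methyl on a saturated chain carbon bound to two saturated chain carbons, or isopentyl to butyl. For the measured compounds named here, no measured step covers this change. Going by the values given here, the only measured step, a 2.3-fold higher number from compound 2 to compound 3 (0.37 log units; beyond the scatter), is hydrogen in place of chloro on an aromatic carbon, so it serves only as a rough guide to size. In this assay, no step beyond the scatter is expected, and the direction is open. The expected step is a 1.2-fold higher number from compound 2 to compound 4 (0.08 log units; within the scatter). Compound 4 is expected at 1800 nM, with an estimated range of 800 nM to 4000 nM.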

Compound 4, concentration for 50% growth inhibition: 2000 nM
For compound 4 the middle estimate is 1.1-fold (0.05 log units) below the measured one; the range from low to high includes it.
By their numbers in this assay, from the lowest: compounds 2, 4, 3 and 1 (each within the scatter of the next, the first and the last beyond it).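

In this assay, going from isopentyl to butyl gives a 1.3-fold higher number from compound 2 to compound 4 (0.12 log units; within the scatter) and so leaves this chain without a change beyond the scatter. With butyl held constant, 3-chlorophenyl in place of 3-chlorobenzyl on the nitrogen gives a 2.2-fold lower number from compound 1 to compound 4 (0.33 log units; beyond the scatter) as a modest step, so here the aromatic nitrogen substituent shifts the number more than the chain change does. From the compounds shown here alone, whether a longer chain, or a chain ending in an amine or a carboxylic acid, would stay within the scatter remains open. No evidence on the reason for either step is available.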